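The compounds below may be only part of what the source reports. "The series", "measured", "known", "first", "only" and "open" are said of these compounds alone.

Measured compounds:
- compound 1 `COc1ccc(/C=C/C(=O)c2ccc(OC)c3c2OC(C)(C)C=C3)cc1OCC=C(C)C` gives > 10000 nM in a functional assay on HepG2 cells (Homo sapiens) for cytotoxicity, read by MTT assay; a lower number here means a stronger inhibitor, a higher number a weaker inhibitor; this is a limit of the assay, not a number.
- compound 2 `CCCCC(=O)Oc1cc(/C=C/C(=O)c2ccc(OC)c3c2OC(C)(C)C=C3)ccc1OC` gives 100 nM in this assay.
- compound 3 `COc1cccc(C(=O)Oc2cc(/C=C/C(=O)c3ccc(OC)c4c3OC(C)(C)C=C4)ccc2OC)c1` gives 870 nM in this assay.

Going by the values given here, compound 1 stands at the weak end of the three: its reading is only a limit, and it is the one value of the three that sits there (the limit of > 10000 nM in this assay, at which 1 of the 3 values shown sits). Both measured steps away from it run the same way. Replacing the ether group on the ring oxygen by an ester gives an at least 100-fold lower number from compound 1 to compound 2 (2.00 log units; beyond the scatter) and an at least 11-fold lower number from compound 1 to compound 3 (1.06 log units; beyond the scatter); between the two esters, an 8.7-fold higher number from compound 2 to compound 3 (0.94 log units; beyond the scatter).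

Compound 4 `COc1ccc(/C=C/C(=O)c2ccc(OC)c3c2OC(C)(C)C=C3)cc1OC(=O)c1ccco1` carries a third ester at the same position: (furan-2-yl)carbonyl in place of 3-methylbut-2-en-1-yl on an oxygen on an aromatic ring. The change from compound 1 is of the same kind as the two measured steps, an acyl group in place of the 3-methylbut-2-en-1-yl group on the aromatic oxygen, so a large drop in the number is expected in this assay, at least as far as the step to compound 3 and plausibly closer to the step to compound 2. The step is estimated as an at least 25-fold lower number from compound 1 to compound 4 (1.39 log units; beyond the scatter).

Compound 4 is expected to give about 400 nM in this assay, with a range from 100 nM to 2000 nM.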

Compound 4, half-maximal inhibitory concentration: 370 nM
The estimate for compound 4 lay 1.1-fold (0.03 log units) above the measured number; the range from low to high includes it.
By their numbers in this assay, from the lowest: compound 2; then compound 4; then compound 3. At a limit, above all of these: compound 1.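

A third acyl group on the aromatic oxygen, this one with a five-membered aromatic ring, again lowers the number in this assay, with an at least 27-fold lower number from compound 1 to compound 4 (1.43 log units; beyond the scatter), so the drop holds for all three esters shown. The group on the carbonyl carbon also sets the level among the esters, with a 2.4-fold lower number from compound 3 to compound 4 (0.37 log units; beyond the scatter) and a 3.7-fold higher number from compound 2 to compound 4 (0.57 log units; beyond the scatter): the two ring-bearing esters, compound 3 and compound 4, do not share one level, and the butyl ester, compound 2, keeps the lowest number. The reading of compound 1 is a limit, so every step from it gives only a bound: the limit of > 10000 nM in this assay, at which 1 of the 4 values shown sits.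

Still open, from the compounds shown here alone, is whether a longer chain on the carbonyl carbon would lower the number beyond that of the butyl ester. Also open, going by these compounds, is whether a carbamate, with an amine on that carbonyl, would keep the drop seen with the esters.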